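Cytotoxicity of Two Aryl Analogues and a Cyano Successor

The source may report more compounds than this note shows. Statements on the series, on what has been measured and on what is new or still open speak of the compounds shown alone.

The compounds share one core and differ only in the aryl group attached to it. Compound 1 `Cc1cncc(-c2ccc3[nH]c(=O)nc(-c4ccccc4)c3c2)c1` carries a methyl-bearing pyridine ring. In an ADME assay on L6 cells (Rattus norvegicus) for cytotoxicity, read by fluorescence and resazurin assay, with a stated time of 72 h (a lower number here means that less compound is needed, a higher number that more compound is needed for the effect), compound 1 gives > 50000 nM, which is a limit of the assay rather than a number. Compound 2 `O=c1nc(-c2ccccc2)c2cc(-c3ccc(F)cc3)ccc2[nH]1` carries a 4-fluorophenyl group instead, and in this assay compound 2 gives 50000 nM. The step of a number no higher from compound 1 to compound 2 (the limit leaves the size open) cannot be sized. Compound 2 therefore holds the only actual number shown; the other value is the limit of > 50000 nM in this assay, at which 1 of the 2 values shown sits. Compound 3 `N#Cc1ccc(-c2ccc3[nH]c(=O)nc(-c4ccccc4)c3c2)cc1` differs from compound 2 by cyano in place of fluoro on an aromatic carbon. Among the measured compounds shown here, no measured step covers this exchange, so the sole guide is that the one step seen, from a pyridine to a fluorophenyl group, remained at the edge of the assay. The step of no change at the digits printed from compound 2 to compound 3 (within the scatter) is expected to stay within the scatter. Compound 3 is estimated at 50000 nM, within 20000 nM to 100000 nM.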

Compound 3, half-maximal effective concentration: > 50000 nM
Compound 3: only a limit was reported (the forecaster's own chance of this, stated with the estimate: 60%); the middle value lies on the limit itself.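

Among the compounds shown here, on the 4-fluorophenyl ring, para to a large group, cyano in place of fluoro gives a number no lower from compound 2 to compound 3 (the limit leaves the size open), so in this assay this change shows no sign of less compound being needed for the effect. The sizes of the steps that end at compound 3 cannot be read, and the aryl groups in this set cannot be ranked against each other. Limits, which are not numbers, now make up most of the results: the limit of > 50000 nM in this assay, at which 2 of the 3 values shown sit.

Going by these compounds, how much compound 3 actually needs for the effect remains open, as does the true gap between the aryl groups. Also open, on these data alone, is whether an amine or a carboxylic acid at this position would give a number that can be read in this assay.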